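Compound 4, a vinylphenyl sulfonamide awaiting its measurement

The source may hold more compounds than are shown below. What is called first, only, known or untested is meant among the compounds shown, and "the series" means these compounds.

Compound 1 `O=S(=O)(Nc1ccc(-c2nc3ccccc3o2)cc1)c1cccc(F)c1` is the starting point. In an assay on isolated protein for inhibition of malate dehydrogenase, mitochondrial (Sus scrofa), with stated times of 45 min and 30 min (a higher number here means a weaker inhibitor, a lower number a stronger inhibitor), compound 1 gives > 63000 nM, which is a limit of the assay and not a number. Compound 2 `COc1cccc(S(=O)(=O)Nc2ccc3oc(-c4ccccc4)nc3c2)c1` gives > 63000 nM in this assay, again a limit. Compound 3 `O=S(=O)(Nc1ccc2oc(-c3ccccc3)nc2c1)c1ccc(Cl)cc1` gives > 63000 nM, likewise a limit. Going by the values given here, the one step recorded between them, a step that the two limits leave unreadable from compound 2 to compound 3, cannot be read because of the limit of > 63000 nM in this assay, at which 3 of the 3 values shown sit.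

Compound 4 `C=Cc1ccc(S(=O)(=O)Nc2ccc(-c3nc4ccccc4o3)cc2)cc1` differs from compound 1 in one place: 4-vinylphenyl in place of 3-fluorophenyl on a sulfonyl sulfur. Among the compounds with values here, no measured step concerns this change, and the only step recorded, from compound 2 to compound 3, is itself unreadable and involves other groups. The expectation for compound 4 therefore rests on the shared picture: because of the limit of > 63000 nM in this assay, at which 3 of the 3 values shown sit, compound 4 is expected to remain near or beyond the limit too. Compound 4 is estimated at 80000 nM in this assay, within 20000 nM to 300000 nM, which as a step means an expected step that the limit leaves unreadable from compound 1 to compound 4.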

Compound 4, half-maximal inhibitory concentration: > 63000 nM
Compound 4: only a limit was reported (the forecaster's own chance of this, stated with the estimate: 85%); the middle value does not contradict the limit.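

Going by these compounds alone, the step from compound 1 to compound 4 cannot be read, and no other new step can, since both values are limits of the assay and not numbers: the limit of > 63000 nM in this assay, at which 4 of the 4 values shown sit.

In this assay the compounds shown leave open how strongly any of them inhibits and whether any group on the sulfonyl sulfur changes that.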